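A few compounds are considered here, and "the series" means these few. Any claim that something is new, unique, unknown or untested is made for them only; others in the source may bear on it.

Results in a functional assay on CCRF-CEM cells (Homo sapiens) for antiproliferative activity, with a stated time of 72 h; a higher number here means a weaker inhibitor, a lower number a stronger inhibitor:
- Compound 1 `COc1cc(CNc2ncnc3c2ncn3[C@@H]2O[C@H](CO)[C@@H](O)[C@H]2O)cc(OC)c1`: > 166000 nM, a limit and not a number
- Compound 2 `OC[C@H]1O[C@@H](n2cnc3c(NCc4ccc(F)cc4F)ncnc32)[C@H](O)[C@@H]1O`: 7100 nM
- Compound 3 `OC[C@H]1O[C@@H](n2cnc3c(NCc4c(F)ccc(F)c4F)ncnc32)[C@H](O)[C@@H]1O`: 90300 nM

Compound 3 holds the higher of the two true numbers, with a 13-fold higher number from compound 2 to compound 3 (1.10 log units; beyond the scatter). Compound 4 `Cc1cccc(CNc2ncnc3c2ncn3[C@@H]2O[C@H](CO)[C@@H](O)[C@H]2O)c1O` carries 2-hydroxy-3-methylphenyl in place of 2,3,6-trifluorophenyl, on a saturated chain carbon bound to a nitrogen on an aromatic ring: 2-hydroxy-3-methylphenyl in place of 2,3,6-trifluorophenyl on a saturated chain carbon bound to a nitrogen on an aromatic ring. Swapping this group has mattered before, as an at least 23-fold lower number from compound 1 to compound 2 (1.36 log units; beyond the scatter) also shows. Among the measured compounds shown here, no measured compound carries a hydroxy group on this ring, so the size of the next step is uncertain. Compound 3 sits high at 90300 nM, while compound 2 reached 7100 nM, so a drop is the likelier direction. The expected change is a 9.0-fold lower number from compound 3 to compound 4 (0.96 log units; beyond the scatter). For compound 4 the estimate is 10000 nM, with an expected range of 1500 nM to 60000 nM.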

Compound 4, half-maximal inhibitory concentration: 900 nM
For compound 4 the middle estimate is 11-fold (1.05 log units) above the measured one; measured number outside the range, below it.
By their numbers in this assay, from the lowest: compound 4; then compound 2; then compound 3. At a limit, above all of these: compound 1.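

With 2-hydroxy-3-methylphenyl on the saturated chain carbon, the number falls against both fluorinated rings, with a 100-fold lower number from compound 3 to compound 4 (2.00 log units; beyond the scatter) and a 7.9-fold lower number from compound 2 to compound 4 (0.90 log units; beyond the scatter) in the two comparisons. Compound 4, the only one shown with a hydroxy group on this ring, therefore has the lowest true number. Compound 1 stands at a limit and not a number, so an at least 180-fold lower number from compound 1 to compound 4 (2.26 log units; beyond the scatter) gives only a floor: the limit of > 166000 nM in this assay, at which 1 of the 4 values shown sits.

Hydroxy and methyl enter together, so their separate shares in this drop stay open. Also open, on these data alone, is whether an amine or a carboxylic acid in place of the hydroxy group would keep the number this low.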